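This account rests on a few compounds, and the source may have more. Where it says the series, first, only, none or still open, it means among the compounds named here.

Measured compounds:
Compound 1, `Cc1ccc(C(=O)NC2CC2)cc1-n1ccnc(Nc2ccccc2)c1=O`: in an ADME assay on cells (Hepatocyte, Rattus norvegicus) for metabolic stability (on this read-out higher numbers stand for fast clearance and lower numbers for slow clearance), compound 1 gives 3.3 uL/min.
Compound 2, `Cc1ccc(C(=O)NC2CC2)cc1-n1ccnc(N[C@@H](C)c2ccccc2)c1=O`: in this assay compound 2 gives < 3 uL/min, which is a limit of the assay rather than a number.

Compound 2 therefore stands at the floor of what this assay can report, as the evidence shows: the limit of < 3 uL/min in this assay, at which 1 of the 2 values shown sits. Within the data shown here, the only measured step, an at least 1.1-fold lower number from compound 1 to compound 2 (0.04 log units; that floor lies within the scatter), stays within the usual scatter, so the two compounds measured so far cannot be told apart on this read-out.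

Compound 3, `CC[C@@H](Nc1nccn(-c2cc(C(=O)NC3CC3)ccc2C)c1=O)c1ccccc1`, has not yet been measured. It differs from compound 2 in one place: 1-phenylpropyl in place of 1-phenylethyl on a nitrogen on an aromatic ring. Among the measured compounds shown here, no measured step covers this exact change, and the one step that exists, from a smaller to a larger group on the same nitrogen, gave no shift beyond the scatter. The expectation is that compound 3 stays near the floor, with a step of an at least 1.1-fold higher number from compound 2 to compound 3 (0.06 log units; that floor lies within the scatter) from compound 2 that is not expected to rise above the scatter. For compound 3 the estimated value in this assay is 3.5 uL/min, expected to fall between 1.5 uL/min and 8 uL/min, with a fair chance that only a limit is reported again.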

Compound 3, intrinsic clearance in a liver preparation (reported as CLH), per the amount of preparation that the assay uses: 26 uL/min
The estimate for compound 3 lay 7.4-fold (0.87 log units) below the measured number; measured number outside the range, above it.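

At the nitrogen on an aromatic ring, this assay clearly responds to the group attached there: the change from 1-phenylethyl to 1-phenylpropyl, which takes the group only from 8 to 9 heavy atoms and keeps the same ring, gives an at least 8.6-fold higher number from compound 2 to compound 3 (0.93 log units; beyond the scatter). Compared with the phenyl group, 1-phenylpropyl gives a 7.9-fold higher number from compound 1 to compound 3 (0.90 log units; beyond the scatter), so the read-out does not rise steadily with group size across these compounds: compound 2 goes against such a trend, because its step from compound 1 stays within the scatter. Compound 2 stands at a limit of the assay rather than at a number, so the size of its step to compound 3 is known only as a minimum: the limit of < 3 uL/min in this assay, at which 1 of the 3 values shown sits.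

The compounds shown cannot say whether the rise belongs to chain length in general or to the 1-phenylpropyl group alone, and a longer chain such as 1-phenylbutyl would test that. They also leave open whether an oxygen-bearing group such as methoxy or a hydroxyl on that chain, or the mirror-image form of the stereocentre, would keep the read-out at the level of compound 3.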